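A fluoro group added to compound 3

The compounds below may be only part of what the source reports. "The series", "measured", "known", "first", "only" and "open" are said of these compounds alone.

Compound 1 `Cn1c(COc2cccc(C(=O)O)c2)nc2ccc(Oc3ccc(Cl)c(F)c3)nc21` gives 25.6 10^-6 cm/s
Compound 2 `Cn1c(COc2cccc(C(=O)O)c2)nc2cnc(Oc3ccc4c(c3)CCC4)cc21` gives 16.5 10^-6 cm/s
Compound 3 `Cc1ccc(Oc2ccc3nc(COc4cccc(C(=O)O)c4)n(C)c3c2)nc1` gives 4.8 10^-6 cm/s

All three compounds were measured in an ADME assay for permeability, using PAMPA, with a stated time of 4 h (a higher number here means that the compound crosses the layer faster, a lower number that the compound crosses the layer more slowly), and the numbers differ widely. Compound 3 stands lowest of the three, and both of the others lie above it by more than the usual scatter of this kind of measurement.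

Compound 4 `Cc1cnc(Oc2ccc3nc(COc4cccc(C(=O)O)c4)n(C)c3c2)c(F)c1` has not been measured yet. It differs from compound 3 in one place: the 5-methylpyridin-2-yl group becomes 3-fluoro-5-methylpyridin-2-yl. The counted change is fluoro in place of hydrogen on an aromatic carbon and in plain terms it is fluoro in place of hydrogen on an aromatic carbon.

Going by the values given here, no two measured compounds differ in only one place, so the data give no direct measure of a step like this one. Among the compounds with values here, compound 1 is the only measured compound that carries a fluoro group and it reaches 25.6 10^-6 cm/s in this set, but it also differs from compound 3 elsewhere, so this is only a weak hint. A small rise is therefore expected, near the edge of the scatter, and the estimated size is a 1.7-fold higher number from compound 3 to compound 4 (0.22 log units; within the scatter) for this change. For compound 4 the expected value is 8 10^-6 cm/s with an estimated range from 3.5 10^-6 cm/s to 18 10^-6 cm/s in this assay once it is measured.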

Compound 4, apparent permeability: 5.8 10^-6 cm/s
Beside the measured number, compound 4's estimate is 1.4-fold (0.14 log units) above it; the measured number falls inside the stated range.
By their numbers in this assay, from the lowest: compounds 3 and 4 (each within the scatter of the next); then compounds 2 and 1 (each within the scatter of the next).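

Going by these compounds alone, compounds 3 and 4 form the first pair in this set that differs in only one place, so they give a direct reading of a single change rather than a hint drawn from compounds that differ in several places. In this assay, placing fluoro on this aromatic carbon, two atoms from the ring nitrogen and ortho to a large group, gives a 1.2-fold higher number from compound 3 to compound 4 (0.08 log units; within the scatter), so this one pair shows no difference that can be told apart from the ordinary spread of repeated measurements. No measured property is available to explain this reading.

The compounds shown carry only hydrogen or fluoro on this carbon, so it remains open whether a different group there, such as methoxy, a nitrile or an amine, would give a step beyond the scatter. From the compounds shown here alone, it also remains open whether fluoro in place of hydrogen would give a similar step on the other aromatic carbons of this ring, or on the ether-linked rings of compound 1 and compound 2.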